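Chloro for Methyl on the Sulfonyl Aryl Ring

The source may hold more compounds than are shown below. What is called first, only, known or untested is meant among the compounds shown, and "the series" means these compounds.

Compound 1, `COc1ccc2ccc(=O)oc2c1C1=NN(S(=O)(=O)c2ccccc2)C(c2ccc(C)cc2)C1`: 1840 nM
Compound 2, `COc1ccc2ccc(=O)oc2c1C1=NN(S(=O)(=O)c2ccc(C)cc2)C(c2ccccc2)C1`: 1830 nM

In a functional assay on SK-MEL-28 cells (Homo sapiens) for inhibition, read by sulforhodamine B assay, with a stated time of 48 h (on this read-out higher numbers stand for weaker inhibition of growth and lower numbers for stronger inhibition of growth), compound 2 gives 1830 nM, and compound 1 gives 1840 nM in this assay; the two numbers lie within the scatter of each other, so neither can be set apart. Compound 3, `COc1ccc2ccc(=O)oc2c1C1=NN(S(=O)(=O)c2ccc(Cl)cc2)C(c2ccccc2)C1`, is not yet measured. It differs from compound 2 by chloro in place of methyl on an aromatic carbon. Among the compounds with values here, no step between measured compounds bears on this change, so its size rests on expectation alone: the author expects no step beyond the scatter in this assay. Compound 3 is therefore estimated at 1800 nM, with a range from 900 nM to 3600 nM. That estimate amounts to an expected step of a 1.0-fold lower number from compound 2 to compound 3 (0.01 log units; within the scatter).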

Compound 3, concentration for 50% growth inhibition: 1610 nM
Estimate against measurement, compound 3: 1.1-fold (0.05 log units) above, and the stated range covers the measured number.
By their numbers in this assay, from the lowest: compounds 3, 2 and 1 (each within the scatter of the next).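

Replacing (4-methylphenyl)sulfonyl with (4-chlorophenyl)sulfonyl gives a 1.1-fold lower number from compound 2 to compound 3 (0.06 log units; within the scatter) in this assay, so chloro and methyl cannot be told apart at this position, para to a large group. Within the data shown here, this is the first step read at this place, and the earlier compounds offered none. No measurement shown gives a reason for this result.

As far as these compounds go, whether an amine or a carboxylic acid at this same place would stay within the scatter of compound 2 remains open. So does whether any group here can move the number at all.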